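The source may hold more compounds than are shown below. What is called first, only, known or untested is meant among the compounds shown, and "the series" means these compounds.

Measured compounds:
Compound 1 `CCOC(=O)C1=Cc2ccccc2OC1(OCc1cn(-c2ccc(F)cc2)nn1)C(F)(F)F` in a functional assay on HeLa cells (Homo sapiens) for inhibition, read by MTT assay, with a stated time of 24 h (a lower number here means a stronger inhibitor, a higher number a weaker inhibitor), gives 8400 nM.
Compound 2 `COc1ccc(-c2cc(COC3(C(F)(F)F)Oc4ccccc4C=C3C(=O)O)on2)cc1` in this assay gives > 150000 nM, which is a limit of the assay and not a number.
Compound 3 `CCOC(=O)C1=Cc2ccccc2OC1(OCc1cc(-c2ccc(C)cc2)no1)C(F)(F)F` in this assay gives > 150000 nM, which again is a limit of the assay and not a number.

Among the compounds with values here, compound 1 thus stands alone among the three as the only one with a number in this assay; the other two sit at the limit of > 150000 nM in this assay, at which 2 of the 3 values shown sit, so no order among them can be read off, and no step between measured compounds is available to guide what follows.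

Compound 4 `CCOC(=O)C1=Cc2ccccc2OC1(OCc1cn(CC(=O)Nc2cccc(Cl)c2)nn1)C(F)(F)F` has not yet been measured in this assay. It differs from compound 1 in one place: ((3-chlorophenyl)carbamoyl)methyl in place of 4-fluorophenyl on an aromatic nitrogen. No pair of measured compounds carries this same change, so the size and direction of the step it brings are unknown, and nothing shown points to any particular effect of the group that enters or the one that leaves.

With that in mind, the expectation is a step of a 1.4-fold higher number from compound 1 to compound 4 (0.15 log units; within the scatter), which is expected to stay within or only just beyond the usual scatter, in either direction. For compound 4 the estimate in this assay is 12000 nM, with a range from 3000 nM to 80000 nM.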

Compound 4, half-maximal inhibitory concentration: 12300 nM
Estimate against measurement, compound 4: 1.0-fold (0.01 log units) below; the range from low to high includes it.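

In this assay, ((3-chlorophenyl)carbamoyl)methyl in place of 4-fluorophenyl on an aromatic nitrogen gives a 1.5-fold higher number from compound 1 to compound 4 (0.17 log units; within the scatter), so this position now carries two different groups whose results cannot be told apart. The entering group has 11 heavy atoms against 7 for the group that leaves, and it brings 1 hydrogen-bond donor and 1 hydrogen-bond acceptor where 4-fluorophenyl has neither, yet this larger substituent, which keeps a six-membered aromatic ring of carbon only, leaves the reading within the scatter. Nothing shown gives a cause for this outcome.

The compounds shown leave open which part of the entering group matters, since the amide, the methylene link and the chlorine arrive together and no compound carries any of them alone. They also leave open whether this nitrogen would accept a group without an aromatic ring, such as a simple ethyl chain or a longer chain ending in an amine, and whether any group placed there could move the number beyond the scatter in either direction.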